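Para-substituent swap on the anilide of the spiro series

The source may report more compounds than this note shows. Statements on the series, on what has been measured and on what is new or still open speak of the compounds shown alone.

Compound 1 `O=C(CN1C(=O)NC2(C1=O)c1ccccc1-c1ccccc12)Nc1ccc(Cl)cc1` gives 80.4% in a functional assay on the whole organism (strain BALB/c) with Mus musculus as the target, with a stated time of 8 h, at a dose of 10 mg/kg; on this read-out higher numbers stand for more inhibition at the one dose given (going by the name of the read-out) and lower numbers for less inhibition. Compound 2 `O=C(CN1C(=O)NC2(C1=O)c1ccccc1-c1ccccc12)Nc1ccc(Br)cc1` gives 81.1% in this assay. For the measured compounds named here, the only measured step is a number 0.7 percentage points higher from compound 1 to compound 2 (within the scatter), so of the two numbers compound 2 sits level with compound 1 rather than apart from it. Compound 3 `Cc1ccc(NC(=O)CN2C(=O)NC3(C2=O)c2ccccc2-c2ccccc23)cc1` is not yet measured; it differs from compound 2 as methyl in place of bromo on an aromatic carbon. Going by the values given here, the one measured step bears on it only loosely, as it exchanged one halogen for another and stayed within the scatter, whereas here a methyl enters. Among the compounds with values here, with no step of this kind on hand, the expectation for compound 3 is a change in this assay of about a number 3.1 percentage points lower from compound 2 to compound 3 (within the scatter), that is none beyond the scatter. For compound 3 the estimated inhibition in this assay is 78%, with a range from 64% to 88%.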

Compound 3, a percentage reported as inhibition, in the whole organism at one dose (the size of the read-out at that dose, not a potency): 53.4%
Beside the measured number, compound 3's estimate is 24.6 percentage points above it; the whole stated range lies above it.
By their numbers in this assay, from the lowest: compound 3; then compounds 1 and 2 (each within the scatter of the next).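

Unlike the exchange of one halogen for another, placing a methyl on this aromatic carbon shifts the read-out in this assay: there is a number 27.7 percentage points lower from compound 2 to compound 3 (beyond the scatter), and likewise a number 27 percentage points lower from compound 1 to compound 3 (beyond the scatter). The position therefore does not accept every small group alike: among these three compounds, 4-bromophenyl and its chloro counterpart read level, while 4-methylphenyl stands apart from both, although one methyl compound cannot establish a wider pattern. No measurement at hand bears on what separates the methyl from the two halogens.

From the compounds shown here alone, it remains open whether the drop belongs to methyl alone or extends to other non-halogen groups, such as a methoxy, an amine or a carboxylic acid on the same carbon. Also open, going by these compounds, is whether a fluoro would stay level with the other halogens, and whether an ethyl would follow the methyl.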